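Compound 2: nitro in place of 2-methoxyethoxy

A few compounds are considered here, and "the series" means these few. Any claim that something is new, unique, unknown or untested is made for them only; others in the source may bear on it.

Compound 1 `COCCOc1cc(/C=C/c2ccc3ccccc3c2)ccc1OC` has its double bond drawn E, and compound 2 `COCCOc1cc(/C=C\c2ccc3ccccc3c2)ccc1OC` has it drawn Z. In a functional assay on A549 cells (Homo sapiens) for inhibition (a lower number here means a stronger inhibitor, a higher number a weaker inhibitor), compound 1 gives 2990 nM, and compound 2 gives 2990 nM, so compound 2 stands level with compound 1. Among the compounds with values here, the only measured step is no change at the digits printed from compound 1 to compound 2 (within the scatter). It concerns configuration alone, as shown by the fact that compounds 1 and 2 differ only in the configuration as drawn.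

Compound 3 `COc1ccc(/C=C\c2ccc3ccccc3c2)cc1[N+](=O)[O-]` keeps the Z double bond of compound 2 and carries nitro in place of 2-methoxyethoxy on an aromatic carbon, ortho to a methoxy group: nitro in place of 2-methoxyethoxy on an aromatic carbon. Within the data shown here, no measured step touches this substituent, so the step at the double bond gives no guide to size or direction here. The anchor is therefore compound 2 at 2990 nM, with a wide margin expected on both sides. The expected shift in this assay is modest and uncertain in direction, an estimated 1.5-fold lower number from compound 2 to compound 3 (0.17 log units; within the scatter). For compound 3 the estimate is 2000 nM, with an expected range from 300 nM to 10000 nM.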

Compound 3, half-maximal inhibitory concentration: > 20000 nM
Compound 3 was reported as a limit; the forecaster's own chance of this, stated with the estimate: 10%; at least 10-fold (1.00 log units) between middle value and limit.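

Compound 3 is reported only as a limit in this assay, > 20000 nM. The earlier pair showed only that configuration at the double bond leaves the read-out unmoved, no change at the digits printed from compound 1 to compound 2 (within the scatter), whereas the substituent on the aromatic carbon ortho to a methoxy group does matter here: nitro in place of 2-methoxyethoxy gives an at least 6.6-fold higher number from compound 2 to compound 3 (0.82 log units; beyond the scatter). Within the data shown here, this is the first change to move the read-out beyond the scatter, and its size is bounded on one side only: the limit of > 20000 nM in this assay, at which 1 of the 3 values shown sits.

The compounds shown do not separate the effect of nitro entering from the effect of 2-methoxyethoxy leaving, and a simple methoxy, an amine or a longer ether chain on the same carbon would be needed to tell these apart. Whether the indifference to configuration seen with 2-methoxyethoxy also holds with nitro remains open, as the nitro compound shown carries only the Z double bond.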